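Dropping the butyl group from compound 2

A few compounds are considered here, and "the series" means these few. Any claim that something is new, unique, unknown or untested is made for them only; others in the source may bear on it.

- compound 1 (`Cc1cccc(NS(=O)(=O)c2ccc(N3CCNC3=O)cc2)c1`) measured at 110 nM 
- compound 2 (`CCCCc1ccc(NS(=O)(=O)c2ccc(N3CCNC3=O)cc2)cc1`) measured at 610 nM 

In a functional assay on HT-29 cells (Homo sapiens) for antiproliferative activity, read by sulforhodamine B assay, with a stated time of 48 h (on this read-out lower numbers stand for stronger inhibition and higher numbers for weaker inhibition), compound 2 holds the higher of the two numbers, and its gap to compound 1 lies beyond the scatter. Compound 3 (`O=C1NCCN1c1ccc(S(=O)(=O)Nc2ccccc2)cc1`) carries hydrogen in place of butyl on an aromatic carbon, para to a large group (hydrogen in place of butyl on an aromatic carbon). Among the compounds with values here, no measured pair isolates this change, so the only guide is the lower number of compound 1 (110 nM). A modest move to a lower number in this assay is expected (a 2.4-fold lower number from compound 2 to compound 3 (0.39 log units; beyond the scatter)). For compound 3 the estimated value is 250 nM with an expected range (80 nM to 800 nM).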

Compound 3, half-maximal inhibitory concentration: 280 nM
For compound 3 the middle estimate is 1.1-fold (0.05 log units) below the measured one; measured number inside the range.
By their numbers in this assay, from the lowest: compound 1; then compound 3; then compound 2.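

In this assay, a 2.2-fold lower number from compound 2 to compound 3 (0.34 log units; beyond the scatter), so butyl on this aromatic carbon, para to a large group, is not needed for activity and stands with a weaker number than hydrogen. Methyl reads the opposite way, with a 2.5-fold higher number from compound 1 to compound 3 (0.41 log units; beyond the scatter), so compound 3 lies between the two alkyl compounds, which differ from each other in more than one place. Nothing available explains either step.

Going by these compounds, it remains open how methyl, ethyl or a carboxylic acid would read on the carbon that carries butyl in compound 2. On these data alone, whether chain length alone sets the number also remains open.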